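A Small Side-Chain Swap Between Compound 2 and Compound 4

This account rests on a few compounds, and the source may have more. Where it says the series, first, only, none or still open, it means among the compounds named here.

Of the compounds shown here, three have been measured in a functional assay on CHO cells for antagonist activity at sphingosine 1-phosphate receptor 2 (Homo sapiens), read by calcium flux; a higher number here means a weaker inhibitor, a lower number a stronger inhibitor. Compound 1 `CCOc1cc2[nH]c(Cc3nn(CC(=O)O)c(=O)c4ccccc34)nc2cc1Cl` gives 17 nM, compound 2 `COC(C(=O)O)c1nn(Cc2cn3cc(OCC4CC4)c(Cl)cc3n2)c2ccccc2c1=O` gives 23 nM, and compound 3 `O=C(Cc1nn(C2CCNC2)c(=O)c2ccccc12)Nc1ccc(OC(F)(F)F)c(Cl)c1` gives 94 nM. Among these three numbers, compound 2 has the second highest; it lies within the scatter of compound 1, whereas compound 3 sits beyond the scatter above it.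

Compound 4 `C[C@H](C(=O)O)c1nn(Cc2cn3cc(OCC4CC4)c(Cl)cc3n2)c2ccccc2c1=O` has not yet been measured. It differs from compound 2 in one place: 1-carboxyethyl in place of carboxy(methoxy)methyl on an aromatic carbon. Among the measured compounds shown here, no pair of measured compounds shows a change of this kind, so there is no earlier step to lean on. The step of a 1.1-fold higher number from compound 2 to compound 4 (0.04 log units; within the scatter) is expected to stay within the scatter, in no clear direction. Compound 4 is therefore estimated at 25 nM, with a range from 9 nM to 70 nM.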

Compound 4, half-maximal inhibitory concentration: 3.2 nM
Compound 4: middle estimate off by 7.8-fold (0.89 log units), on the high side; measured number outside the range, below it.
By their numbers in this assay, from the lowest: compound 4; then compounds 1 and 2 (each within the scatter of the next); then compound 3.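

In this assay, putting 1-carboxyethyl in place of carboxy(methoxy)methyl gives a 7.2-fold lower number from compound 2 to compound 4 (0.86 log units; beyond the scatter) on this aromatic carbon, so the number responds clearly to a small change in this side chain. The change both removes the methoxy part and brings in a defined stereocentre, and this single pair cannot tell which of the two matters. No measurement shown here explains the shift.

From the compounds shown here alone, it remains open how the mirror-image form of 1-carboxyethyl would behave. Also open, going by these compounds, is whether a longer chain such as 1-carboxypropyl, or an amine in place of the carboxylic acid, would keep the number this low.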